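The source may report more compounds than this note shows. Statements on the series, on what has been measured and on what is new or still open speak of the compounds shown alone.

Compound 1 `CCOC(=O)Cn1c(=O)n(C2OC(CO)[C@@H](O)[C@H]2O)c2nc(N)nc(O)c21` gives 58% in a functional assay on the whole organism with Mus musculus as the target; a lower number here means a smaller maximal response, a higher number a larger maximal response.
Compound 2 `CCCCCCCCCCn1c(=O)n(C2OC(CO)[C@@H](O)[C@H]2O)c2nc(N)nc(O)c21` gives 0% in this assay.
Compound 3 `CCCCCCn1c(=O)n(C2OC(CO)[C@@H](O)[C@H]2O)c2nc(N)nc(O)c21` gives 11% in this assay.

Compound 3 stands second highest of the three numbers: compound 1 lies well above it and compound 2 a little below it, both gaps beyond the scatter. The unmeasured compound 4 `Nc1nc(O)c2c(n1)n(C1OC(CO)[C@@H](O)[C@H]1O)c(=O)n2CCN1CCCCC1` differs from compound 3 in one place: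

piperidin-1-yl in place of butyl on a saturated chain carbon, two bonds along the chain from an aromatic nitrogen

For the measured compounds named here, no measured step exchanges a plain alkyl chain for a saturated ring of this kind, so the measured steps bear on the change only in part. The steps of a number 58 percentage points lower from compound 1 to compound 2 (beyond the scatter) and a number 47 percentage points lower from compound 1 to compound 3 (beyond the scatter) show that a plain alkyl chain in place of ethoxycarbonyl costs most of the response in this assay. The step of a number 11 percentage points higher from compound 2 to compound 3 (beyond the scatter) is the closest to the present change, since it also removes a butyl, and it brought a modest gain. Going by the values given here, the entering piperidin-1-yl has no measured counterpart here, so the width of the expectation is large. On this basis the step is expected to be modest and upward, a number 14 percentage points higher from compound 3 to compound 4 (beyond the scatter). Compound 4 is therefore estimated to reach 25%, with a range from 5% to 55%.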

Compound 4, largest response reached (reported as maximal response), in percent of the reference or control that the assay uses: 0%
Estimate against measurement, compound 4: 25 percentage points above, outside the stated range (below it).
By their numbers in this assay, from the lowest: compounds 2 and 4 (each within the scatter of the next); then compound 3; then compound 1.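

In this assay, piperidin-1-yl in place of butyl, on a saturated chain carbon two bonds along the chain from an aromatic nitrogen, gives a number 11 percentage points lower from compound 3 to compound 4 (beyond the scatter), so the gain seen when a butyl left in the step from compound 2 to compound 3 does not recur with this ring. Against the longer chain the ring gives no change at the digits printed from compound 2 to compound 4 (within the scatter), and against the ester it gives a number 58 percentage points lower from compound 1 to compound 4 (beyond the scatter), so compound 1 remains well above the other three and the low response at this position is no longer confined to plain alkyl chains. Nothing at hand explains why the response falls with this ring.

The compounds shown leave open whether the response of compound 1 depends on the ethoxycarbonyl as such, or would also appear with a carboxylic acid or a primary amide on the same chain carbon. They also leave open whether a morpholine ring, an open-chain dimethylamino group or a short ethyl chain at this position would lie nearer to compound 3 or to compound 1.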